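A few compounds are considered here, and "the series" means these few. Any claim that something is new, unique, unknown or untested is made for them only; others in the source may bear on it.

Measured compounds in this series:

compound 1, `ClCc1ccc(Cn2cnc3c(Cl)ncnc32)cc1`: 36300 nM
compound 2, `Nc1nc(Cl)c2ncn(Cc3ccc(CCl)cc3)c2n1`: 43700 nM
compound 3, `ClCc1ccccc1Cn1cnc2c(Cl)ncnc21`: the assay gives only a limit, > 100000 nM

In a functional assay on DU-145 cells (Homo sapiens) for cytotoxicity, read by sulforhodamine B assay, with a stated time of 48 h (on this read-out higher numbers stand for lower toxicity in this test and lower numbers for higher toxicity in this test), compound 1 gives 36300 nM. Compound 2 differs from compound 1 by amino in place of hydrogen on an aromatic carbon. The step measured for this change, a 1.2-fold higher number from compound 1 to compound 2 (0.08 log units; within the scatter), lies within the scatter of the method, so the two values of compound 1 and compound 2 are to be read as the same. Compound 3 has the same atoms as compound 1 joined differently; the difference between the two cores is not broken down here. For compound 3 this assay reports only a limit, > 100000 nM, and that limit is the limit of > 100000 nM in this assay, at which 1 of the 3 values shown sits.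

Compound 4, `Nc1nc(Cl)c2ncn(Cc3ccccc3CCl)c2n1`, has not yet been measured in this assay. Within the data shown here, it differs from compound 3 by amino in place of hydrogen on an aromatic carbon, which is the same change as the one from compound 1 to compound 2, at the same kind of place. The expected step that the limit leaves unreadable from compound 3 to compound 4 is estimated to be small because the measured step of a 1.2-fold higher number from compound 1 to compound 2 (0.08 log units; within the scatter) is within scatter. Since compound 3 already sits at the limit, compound 4 is expected to be reported at or near that limit as well. The estimated value for compound 4 is 130000 nM, with an expected range from 70000 nM to 400000 nM.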

Compound 4, concentration lethal to 50% of the cells: 70800 nM
The estimate for compound 4 lay 1.8-fold (0.26 log units) above the measured number, within the range that was stated.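

In this assay, amino in place of hydrogen on an aromatic carbon gives an at least 1.4-fold lower number from compound 3 to compound 4 (0.14 log units; that floor lies within the scatter), and that figure is a floor rather than a measured size of the step. From the compounds shown here alone, compound 3 stands at a limit of the assay, > 100000 nM, so the true size of the step on this core stays unknown, and the floor alone cannot fix it. The result therefore shows neither that the change carries over unaltered from the core of compound 1 to the core of compound 3 nor that it behaves differently there, and the two cores can be set side by side only this far: the same change on two cores in this assay, a 1.2-fold higher number (0.08 log units; within the scatter) from compound 1 to compound 2 and an at least 1.4-fold lower number (0.14 log units; that floor lies within the scatter) from compound 3 to compound 4; the limit leaves it open whether they differ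

The compounds shown leave open what other groups would give on the same aromatic carbon, for instance a methylamino group, a dimethylamino group, a hydroxyl group or a methoxy group in place of the amino group. Also open, going by these compounds, is what a bromomethyl or a hydroxymethyl group would give in place of the chloromethyl group on either core, and whether the amino change would then keep its size.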